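The compounds below may be only part of what the source reports. "The series", "measured", "known", "first", "only" and "open" are said of these compounds alone.

Compounds measured so far:

Compound 1, `Cc1cc(C)n(CCOC2CC(=O)Nc3c2c(C)nn3-c2ncnc3nc[nH]c23)n1`: 2000 nM
Compound 2, `Cc1nn(-c2ncnc3nc[nH]c23)c2c1C(OC(=O)c1ccc(F)cc1)CC(=O)N2`: 245 nM
Compound 3, `Cc1nn(-c2ncnc3nc[nH]c23)c2c1C(OCCn1cccn1)CC(=O)N2`: 2270 nM

In a functional assay on HEK293 cells for agonist activity at G-protein coupled receptor 39 (Homo sapiens), read by scintillation proximity assay and inositol phosphate accumulation, with a stated time of 75 min (a lower number here means that less compound is needed, a higher number that more compound is needed for the effect), compound 3 gives the highest of the three numbers. Its nearest neighbour is compound 1, since the step of a 1.1-fold higher number from compound 1 to compound 3 (0.05 log units; within the scatter) lies within the scatter; the step of a 9.3-fold higher number from compound 2 to compound 3 (0.97 log units; beyond the scatter) sets compound 2 well apart, and likewise an 8.2-fold lower number from compound 1 to compound 2 (0.91 log units; beyond the scatter) shows that the ester of compound 2 stands out from both ethers.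

Compound 4, `Cc1nn(-c2ncnc3nc[nH]c23)c2c1C(OCCn1nccc1C)CC(=O)N2`, differs from compound 3 by methyl in place of hydrogen on an aromatic carbon. Among the compounds with values here, the measured step that bears on this is the one from compound 1 to compound 3, where the loss of both methyl groups of the 3,5-dimethyl-1H-pyrazol-1-yl group changed the number by a 1.1-fold higher number from compound 1 to compound 3 (0.05 log units; within the scatter), within the scatter. Putting one methyl back, in the 5-position, is therefore expected to move the number by little, if at all, in this assay; the step of a 1.1-fold lower number from compound 3 to compound 4 (0.05 log units; within the scatter) that the estimate implies is expected to stay within the scatter. The expected value for compound 4 is 2000 nM, with a plausible range from 900 nM to 5000 nM.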

Compound 4, half-maximal effective concentration: 1620 nM
Beside the measured number, compound 4's estimate is 1.2-fold (0.09 log units) above it; measured number inside the range.
By their numbers in this assay, from the lowest: compound 2; then compounds 4, 1 and 3 (each within the scatter of the next).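

Taken alone, methyl in place of hydrogen on this aromatic carbon, next to the ring nitrogen, gives a 1.4-fold lower number from compound 3 to compound 4 (0.15 log units; within the scatter) in this assay; the earlier compounds showed only the two methyl groups of compound 1 changing together, whereas this result separates one of them. The other single change, hydrogen in place of methyl on an aromatic carbon of the same ring, gives a 1.2-fold lower number from compound 1 to compound 4 (0.09 log units; within the scatter), so neither single methyl change moves the number beyond the scatter, and the third ether also stays apart from the ester, with a 6.6-fold higher number from compound 2 to compound 4 (0.82 log units; beyond the scatter). No measurement offered here accounts for these results.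

The compounds shown leave open whether the carbonyl link or the 4-fluorophenyl group sets compound 2 apart from the ethers, as these two parts change together with the rest of the side chain in each step between them. They also leave open how the number would respond to trifluoromethyl or an amine on this aromatic carbon, or to a longer chain between the oxygen and the pyrazole.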